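The source may report more compounds than this note shows. Statements on the series, on what has been measured and on what is new or still open speak of the compounds shown alone.

Measured so far:
compound 1, `O=S(=O)(c1ccc(F)c(F)c1)c1cnc2c(F)cccc2c1-c1ccc(Cl)cc1`: 0.28 mL/min
compound 2, `O=S(=O)(c1cc(F)cc(F)c1)c1cnc2c(F)cccc2c1-c1ccccc1F`: 0.09 mL/min
compound 3, `O=S(=O)(c1cc(F)cc(F)c1)c1cnc2c(F)cccc2c1-c1cccc(F)c1`: 1.18 mL/min

In an ADME assay on microsomes from liver (Homo sapiens) for metabolic stability, tested at 2.5 uM (a lower number here means slower removal, a higher number faster removal of the compound), compound 3 gives the highest number of the three measured compounds. Compound 4, `O=S(=O)(c1cc(F)cc(F)c1)c1cnc2c(F)cccc2c1-c1ccc(Cl)cc1`, is not yet measured in this assay. The change from compound 3 to compound 4 is 4-chlorophenyl in place of 3-fluorophenyl on an aromatic carbon. Going by the values given here, the one measured step that touches this position is a 13-fold higher number from compound 2 to compound 3 (1.12 log units; beyond the scatter), which shows that the pattern of the pendant phenyl ring moves the read-out a good deal. Compound 1 carries the same 4-chlorophenyl as compound 4 on a core that differs only in the sulfonyl ring, and in this assay compound 1 gives 0.28 mL/min. A downward step a 3.0-fold lower number from compound 3 to compound 4 (0.47 log units; beyond the scatter) is therefore expected. Compound 4 is estimated at 0.4 mL/min, with a range of 0.15 mL/min to 1 mL/min.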

Compound 4, intrinsic clearance in a liver preparation (reported as CLH), per the amount of preparation that the assay uses: 0.73 mL/min
Beside the measured number, compound 4's estimate is 1.8-fold (0.26 log units) below it; the range from low to high includes it.
By their numbers in this assay, from the lowest: compound 2; then compound 1; then compounds 4 and 3 (each within the scatter of the next).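

The change of pendant ring in this assay gives a 1.6-fold lower number from compound 3 to compound 4 (0.21 log units; within the scatter) so 4-chlorophenyl and 3-fluorophenyl cannot be told apart at this position, whereas 2-fluorophenyl stands apart with an 8.1-fold higher number from compound 2 to compound 4 (0.91 log units; beyond the scatter) on the same core. With 4-chlorophenyl held fixed, 3,5-difluorophenyl in place of 3,4-difluorophenyl on the sulfonyl sulfur gives a 2.6-fold higher number from compound 1 to compound 4 (0.42 log units; beyond the scatter) so the read-out does not depend on the pendant ring alone. No evidence at hand accounts for these steps.

As far as these compounds go, whether an amine or a carboxylic acid at this position would move the read-out remains open. Also open, from the compounds shown here alone, is whether the sulfonyl ring step carries over to other pendant rings.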